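Pyridin-2-yl replacing 3,4-dichlorophenyl on the shared core

The compounds below may be only part of what the source reports. "The series", "measured", "known", "first", "only" and "open" are said of these compounds alone.

- Compound 1 `Cc1ccc(N2CCN(C(=O)/C=C/c3ccc(O)c(O)c3)CC2)c(C)c1` gives 1.02 ug/mL
- Compound 2 `O=C(/C=C/c1ccc(O)c(O)c1)N1CCN(c2ccc(Cl)c(Cl)c2)CC1` gives 1.74 ug/mL

Both values come from a functional assay on A549 cells (Homo sapiens) for antiproliferative activity, read by MTT assay, with a stated time of 48 h; a higher number here means a weaker inhibitor, a lower number a stronger inhibitor. Compound 2 , at 1.74 ug/mL, lies within the scatter of compound 1 , so the two cannot be ranked. Compound 3 `O=C(/C=C/c1ccc(O)c(O)c1)N1CCN(c2ccccn2)CC1` has not yet been measured. It differs from compound 2 as follows: pyridin-2-yl in place of 3,4-dichlorophenyl on an amine nitrogen in a ring. In short, pyridin-2-yl stands in place of 3,4-dichlorophenyl on an amine nitrogen in a ring. Among the compounds with values here, only one measured step bears on this, a change on that same nitrogen: a 1.7-fold higher number from compound 1 to compound 2 (0.23 log units; within the scatter). Within the data shown here, no measured compound carries a hetero atom in this aromatic ring, so that guide is limited. No step beyond the scatter is therefore expected, though the uncertainty is wide. The expected step is a 1.3-fold higher number from compound 2 to compound 3 (0.10 log units; within the scatter). For compound 3 the estimated value is 2.2 ug/mL, with an expected range from 0.7 ug/mL to 6.5 ug/mL.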

Compound 3, half-maximal inhibitory concentration: 2.32 ug/mL
Compound 3: the middle estimate sits 1.1-fold (0.02 log units) below what was measured; measured number inside the range.
By their numbers in this assay, from the lowest: compounds 1, 2 and 3 (each within the scatter of the next, the first and the last beyond it).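

In this assay, within the data shown here, the amine nitrogen in a ring now carries an aromatic ring with a hetero atom for the first time, and pyridin-2-yl in place of 3,4-dichlorophenyl gives a 1.3-fold higher number from compound 2 to compound 3 (0.12 log units; within the scatter). Pyridin-2-yl in place of 2,4-dimethylphenyl at the same place gives the first step beyond the scatter, a modest one: a 2.3-fold higher number from compound 1 to compound 3 (0.36 log units; beyond the scatter), so compound 1 and compound 3 are the only pair here that can be ranked. No measurement shown gives a reason for these differences.

The compounds shown leave open whether pyridin-3-yl or pyrimidin-2-yl on this nitrogen would read like pyridin-2-yl, and what an unsubstituted phenyl would give. They also leave open what a benzyl or cyclohexyl group would give at this place.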